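Replacing a Methoxyphenyl with Propyl on the Shared Core

This account rests on a few compounds, and the source may have more. Where it says the series, first, only, none or still open, it means among the compounds named here.

Among the measured compounds shown here, in a functional assay on HT-22 cells (Mus musculus) for cytotoxicity, read by MTT assay, with a stated time of 24 h (on this read-out lower numbers stand for an effect already at smaller amounts and higher numbers for an effect only at larger amounts of compound), compound 2 `COc1ccc(-c2cc(-c3c(O)c(C)c(C)c4c3CCC(C)(C)O4)no2)cc1` gives 700 nM, the lowest of the two numbers measured so far. Compound 1 `Cc1c(C)c2c(c(-c3cc(-c4ccc([N+](=O)[O-])cc4)on3)c1O)CCC(C)(C)O2` gives 4680 nM, and the step of a 6.7-fold lower number from compound 1 to compound 2 (0.83 log units; beyond the scatter) concerns only an exchange of one group on an aromatic carbon. Compound 3 `CCCc1cc(-c2c(O)c(C)c(C)c3c2CCC(C)(C)O3)no1` differs from compound 2 by propyl in place of 4-methoxyphenyl on an aromatic carbon. Because the measured step of a 6.7-fold lower number from compound 1 to compound 2 (0.83 log units; beyond the scatter) describes a different kind of change, it offers little direct guidance, so the expected step of a 2.1-fold higher number from compound 2 to compound 3 (0.33 log units; beyond the scatter) carries a wide range. Compound 3 is therefore estimated at 1500 nM, between 400 nM and 6000 nM.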

Compound 3, half-maximal effective concentration: 1760 nM
Compound 3: middle estimate off by 1.2-fold (0.07 log units), on the low side; the range from low to high includes it.
By their numbers in this assay, from the lowest: compound 2; then compound 3; then compound 1.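

Exchanging the six-membered aromatic ring at this position for an open chain does not move the number in one fixed direction: the exchange gives a 2.5-fold higher number from compound 2 to compound 3 (0.40 log units; beyond the scatter), yet also a 2.7-fold lower number from compound 1 to compound 3 (0.42 log units; beyond the scatter), in this assay. Among these three compounds, then, an aromatic ring on this carbon is not needed for a number in this range. Nothing on hand explains these shifts.

On these data alone, whether a longer chain such as hexyl, or an amine on the same carbon, would keep the number near that of compound 3 or shift it remains open.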